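Trading a long chain for a hydroxy group

A few compounds are considered here, and "the series" means these few. Any claim that something is new, unique, unknown or untested is made for them only; others in the source may bear on it.

Of the compounds shown here, three built on the same core have been measured in a functional assay on HeLa cells (Homo sapiens) for antiproliferative activity, read by MTT assay, with a stated time of 72 h; a lower number here means a stronger inhibitor, a higher number a weaker inhibitor. Compound 1, `O=C1O/C(=C\Cn2cc(-c3ccc(Br)cc3)nn2)C(OCc2ccccc2)=C1OCc1ccccc1`, gives 24300 nM. Among the compounds with values here, compound 2, `O=C1O/C(=C\Cn2cc(-c3cc(F)cc(F)c3)nn2)C(OCc2ccccc2)=C1OCc1ccccc1`, gives 17700 nM; the only step measured between two compounds differing in one place is a 1.4-fold lower number from compound 1 to compound 2 (0.14 log units; within the scatter). Compound 3, `CCCCCCCCCCc1cn(C[C@H](O)[C@H]2OC(=O)C(OCc3ccccc3)=C2OCc2ccccc2)nn1`, gives 22900 nM, the second highest of the three numbers, though its gaps to compound 1 and compound 2 both lie within the scatter, so the three cannot be ranked.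

Compound 4, `O=C1O[C@H]([C@@H](O)Cn2cc(CCO)nn2)C(OCc2ccccc2)=C1OCc1ccccc1`, differs from compound 3 in a single place: hydroxy in place of octyl on a saturated chain carbon, two bonds along the chain from an aromatic carbon. Within the data shown here, the one measured step, from compound 1 to compound 2, swaps one aromatic group for another on a different part of the molecule and says nothing about this change at the chain. Among the measured compounds shown here, no measured pair shows what happens when octyl leaves and hydroxy enters. With no direct guide, the expectation is drawn from compound 3 alone, allowing a wide margin in either direction, with a lean toward a larger number. Compound 4 is therefore expected to give about 40000 nM in this assay, within a range of 12000 nM to 130000 nM. That expected step from compound 3 to compound 4 is a 1.7-fold higher number from compound 3 to compound 4 (0.24 log units; within the scatter).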

Compound 4, half-maximal inhibitory concentration: 68800 nM
For compound 4 the middle estimate is 1.7-fold (0.24 log units) below the measured one, within the range that was stated.
By their numbers in this assay, from the lowest: compounds 2, 3 and 1 (each within the scatter of the next); then compound 4.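

In this assay, within the data shown here, trading octyl for hydroxy gives a 3.0-fold higher number from compound 3 to compound 4 (0.48 log units; beyond the scatter) and so yields the first measured step beyond the scatter, though only a modest one. Among these compounds, the earlier step concerned aromatic groups elsewhere on the molecule, so this is the first sign that the number responds to a change on a saturated chain carbon, two bonds along the chain from an aromatic carbon: here, replacing a group of 8 carbon heavy atoms with a single oxygen carrying 1 hydrogen-bond donor goes with a weaker result. No evidence is available to explain this shift.

Because the swap removes one group and adds another, these compounds cannot show whether the loss of octyl, the arrival of hydroxy, or both account for the step, and a shorter chain such as butyl, or a methoxy group or an amine at the same place, would help to separate those possibilities. From the compounds shown here alone, whether the same swap would give a step of similar size on the core of compound 1 also remains open.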